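This account rests on a few compounds, and the source may have more. Where it says the series, first, only, none or still open, it means among the compounds named here.

Measured so far:
compound 1 `CC(C)OCCOc1ccc(/C=C2\SC(=O)NC2=O)c(Cl)c1` — in an assay for inhibition of 15-hydroxyprostaglandin dehydrogenase [NAD(+)] (Homo sapiens), read by fluorescence and spectrophotometry (on this read-out lower numbers stand for stronger inhibition and higher numbers for weaker inhibition), compound 1 gives 1050 nM
compound 2 `O=C1N=C(O)S/C1=C\c1ccc(OCCc2ccccn2)cc1Cl` — compound 2 gives 8920 nM

Among the compounds with values here, compound 1 holds the lowest of the two numbers; compound 2 stands beyond the scatter above it, and no single-point step between the two is available. The next compound, compound 3 `O=C1NC(=O)/C(=C/c2ccc(OCCC3CCCC3)cc2Cl)S1`, differs from compound 1 by cyclopentyl in place of isopropoxy on a saturated chain carbon, two bonds along the chain from an oxygen on an aromatic ring. With no measured step of this kind in the series, the step is expected to be small, in either direction or none beyond the scatter: a 1.3-fold lower number from compound 1 to compound 3 (0.12 log units; within the scatter). Compound 3 is therefore estimated at 800 nM, within 250 nM to 2500 nM.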

Compound 3, half-maximal inhibitory concentration: 42 nM
Estimate against measurement, compound 3: 19-fold (1.28 log units) above, and the stated range ends above it.
By their numbers in this assay, from the lowest: compound 3; then compound 1; then compound 2.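

Cyclopentyl in place of isopropoxy on a saturated chain carbon, two bonds along the chain from an oxygen on an aromatic ring, gives a 25-fold lower number from compound 1 to compound 3 (1.40 log units; beyond the scatter) in this assay and shows that this position responds strongly to the group it carries. The end of the chain therefore matters to this read-out, and an all-carbon ring is well accepted there. Nothing measured on these compounds accounts for the gain.

On these data alone, it remains open whether the ring or the loss of the ether oxygen carries the step. Isobutyl, cyclohexyl or phenyl at this position would help separate the two.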